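The source may report more compounds than this note shows. Statements on the series, on what has been measured and on what is new or still open speak of the compounds shown alone.

Measured so far in a functional assay on MCF7 cells (Homo sapiens) for cytotoxicity, read by MTT assay, with a stated time of 48 h; on this read-out higher numbers stand for weaker inhibition and lower numbers for stronger inhibition:

compound 1 `COc1ccc(-c2cc(C(=O)Nc3nc4ccc(Cl)cc4s3)nc3cc(-c4ccccc4)nn23)cc1` — 4890 nM
compound 2 `COc1ccc(-c2cc(C(=O)Nc3nc4ccc(Cl)cc4s3)nc3cc(-c4ccccc4)nn23)cc1OC` — 6910 nM

Going by the values given here, only two compounds have numbers. In this assay compound 2 sits within the scatter of compound 1: a 1.4-fold higher number from compound 1 to compound 2 (0.15 log units; within the scatter). Nothing in this pair separates the two, so compound 2 stands at the same level as compound 1 for practical purposes.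

Compound 3 `COc1ccc(-c2cc(C(=O)Nc3nc4ccc(F)cc4s3)nc3cc(-c4ccccc4)nn23)cc1OC` is not yet measured. Its change from compound 2 is fluoro in place of chloro on an aromatic carbon. Among the compounds with values here, the one measured step, methoxy in place of hydrogen on an aromatic carbon, is a different change at a different place and gives no direct guidance for a halogen exchange on the fused ring. Within the data shown here, with no bearing step, the expectation is a step within the scatter in this assay, in no particular direction, and the range is set wide.

For compound 3 the estimated value in this assay is 8000 nM, with a range from 3500 nM to 18000 nM. The expected step is a 1.2-fold higher number from compound 2 to compound 3 (0.06 log units; within the scatter).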

Compound 3, half-maximal inhibitory concentration: 22400 nM
Compound 3: the middle estimate sits 2.8-fold (0.45 log units) below what was measured; the whole stated range lies below it.
By their numbers in this assay, from the lowest: compounds 1 and 2 (each within the scatter of the next); then compound 3.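

In this assay the fluoro in place of chloro exchange gives a step beyond the scatter, a 3.2-fold higher number from compound 2 to compound 3 (0.51 log units; beyond the scatter), so this place on the six-membered aromatic ring responds to a single-atom change. The methoxy change gave no such separation, with a 1.4-fold higher number from compound 1 to compound 2 (0.15 log units; within the scatter) lying within the scatter, so of the two places varied only this one has moved the number. At this stage, 6-chloro-1,3-benzothiazol-2-yl is the better of the two groups tested here on the dimethoxy-bearing compounds, though nothing measured explains the difference.

One exchange cannot show whether the number follows a trend across halogens, and bromo, methyl or an amine at this place would test that. Going by these compounds alone, it also remains open whether the same step appears with the single methoxy of compound 1.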